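Swapping cyclopentylmethyl for piperidin-1-yl on a carbonyl carbon

The compounds below may be only part of what the source reports. "The series", "measured", "known", "first", "only" and "open" are said of these compounds alone.

- Compound 1 `NS(=O)(=O)c1ccc(-c2cc(C(=O)C3CC3)nn2-c2ccc(Cl)cc2)cc1`: 25600 nM
- Compound 2 `NS(=O)(=O)c1ccc(-c2cc(C(=O)C3CCC3)nn2-c2ccc(Cl)cc2)cc1`: 17200 nM
- Compound 3 `NS(=O)(=O)c1ccc(-c2cc(C(=O)CC3CCCC3)nn2-c2ccc(Cl)cc2)cc1`: 2600 nM

In a physicochemical assay for solubility, read by HPLC, in phosphate buffer, measured as kinetic solubility, at pH 7.4 (a lower number here means a less soluble compound, a higher number a more soluble compound), compound 3 gives the lowest of the three numbers, 2600 nM. The next change leads to compound 4 `NS(=O)(=O)c1ccc(-c2cc(C(=O)N3CCCCC3)nn2-c2ccc(Cl)cc2)cc1`: piperidin-1-yl in place of cyclopentylmethyl on a carbonyl carbon. In short, piperidin-1-yl stands in place of cyclopentylmethyl on a carbonyl carbon.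

Among the measured compounds shown here, no measured step brings in a ring with a hetero atom, so none matches this change directly. The closest guides are the steps that introduced cyclopentylmethyl: a 9.8-fold lower number from compound 1 to compound 3 (0.99 log units; beyond the scatter) and a 6.6-fold lower number from compound 2 to compound 3 (0.82 log units; beyond the scatter). By contrast, a 1.5-fold lower number from compound 1 to compound 2 (0.17 log units; within the scatter) stayed within the scatter. Together they show that the group on this carbonyl carbon can shift the number by a modest amount.

With cyclopentylmethyl gone, a partial return toward compound 2 at 17200 nM is expected, though this is a weak guide. In this assay, the expected change is a modest rise, a 3.1-fold higher number from compound 3 to compound 4 (0.49 log units; beyond the scatter). The estimate for compound 4 is 8000 nM, with an expected range of 2500 nM to 25000 nM.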

Compound 4, solubility: 65900 nM
Estimate against measurement, compound 4: 8.2-fold (0.92 log units) below; measured number outside the range, above it.
By their numbers in this assay, from the lowest: compound 3; then compounds 2 and 1 (each within the scatter of the next); then compound 4.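

In this assay piperidin-1-yl gives a 25-fold higher number from compound 3 to compound 4 (1.40 log units; beyond the scatter) in place of cyclopentylmethyl on a carbonyl carbon, although both groups hold the same number of heavy atoms, so that count alone does not set the number here. Compound 4 also stands clear of the two compounds with smaller carbon rings, with a 3.8-fold higher number from compound 2 to compound 4 (0.58 log units; beyond the scatter) and a 2.6-fold higher number from compound 1 to compound 4 (0.41 log units; beyond the scatter) in the same swap, so this position can carry the number past anything the carbon-only groups reached. No measurement shown gives a reason for this rise.

Cyclohexyl on the carbonyl carbon would hold a six-membered ring without the nitrogen, and the compounds shown cannot separate ring size from the hetero atom. They also leave open whether morpholin-4-yl or an open-chain amine such as diethylamino would behave like piperidin-1-yl.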